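Swapping a Hexyl Chain for a Fluorinated Ring

The compounds below may be only part of what the source reports. "The series", "measured", "known", "first", "only" and "open" are said of these compounds alone.

This series shares one core, in which a chain carrying a double bond is varied at its far end. Compound 1 `CCCCCC/C=C/C[C@H]1C[C@@H]([C@@H](O)c2ccccc2)CO[C@@H]1c1ccccc1` is that core with a hexyl chain beyond the double bond, and in a functional assay on HL-60 cells (Homo sapiens) for cytotoxicity, read by WST assay, with a stated time of 48 h (on this read-out higher numbers stand for weaker inhibition and lower numbers for stronger inhibition), compound 1 gives 4990 nM. Compound 2 `O[C@@H](c1ccccc1)[C@H]1CO[C@H](c2ccccc2)[C@@H](C/C=C/C2CCCC2)C1` has cyclopentyl in place of hexyl, and in this assay compound 2 gives 9060 nM. Among the two compounds measured, compound 1 holds the lower number, but the gap is small: the step is a 1.8-fold higher number from compound 1 to compound 2 (0.26 log units; within the scatter), so the two cannot be told apart with confidence.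

Compound 3 `O[C@@H](c1ccccc1)[C@H]1CO[C@H](c2ccccc2)[C@@H](C/C=C/c2ccc(F)cc2)C1` again changes the group at the end of the chain: 4-fluorophenyl in place of hexyl on a double-bonded chain carbon bound to a double-bonded chain carbon. Going by the values given here, the only step that speaks to this position is the one from compound 1 to compound 2, and it produced no difference beyond the scatter. Nothing measured here shows how an aromatic ring at this place behaves, so the expectation for compound 3 rests on that single, flat step: the number is expected to stay close to that of compound 1, with a step of about a 1.3-fold higher number from compound 1 to compound 3 (0.11 log units; within the scatter). Compound 3 is therefore estimated at 6500 nM, within a range of 2500 nM to 17000 nM.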

Compound 3, half-maximal inhibitory concentration: 8110 nM
The estimate for compound 3 lay 1.2-fold (0.10 log units) below the measured number; the measured number falls inside the stated range.
By their numbers in this assay, from the lowest: compounds 1, 3 and 2 (each within the scatter of the next).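

In this assay, the first aromatic ring at the end of the chain gives a 1.6-fold higher number from compound 1 to compound 3 (0.21 log units; within the scatter), and replacing the cyclopentyl ring with that same aromatic ring gives a 1.1-fold lower number from compound 2 to compound 3 (0.05 log units; within the scatter). Hexyl, cyclopentyl and 4-fluorophenyl therefore cannot be told apart on a double-bonded chain carbon bound to a double-bonded chain carbon, even though an open chain, a non-aromatic ring and a fluorine-bearing aromatic ring are quite different groups to place there. Nothing available explains why these three groups give numbers that lie so close together.

On these data alone, it remains open whether this insensitivity extends to groups of a different kind at the same place, such as an amine, a carboxylic acid, a longer chain or a phenyl ring without its fluorine, and whether any of them would give a step beyond the scatter. With only these three compounds in this assay, it also remains open whether the fluorine itself matters, since no pair shown differs by that atom alone.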